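Swapping the Ring on the Amide Nitrogen, Starting From a Limit

The compounds below may be only part of what the source reports. "The series", "measured", "known", "first", "only" and "open" are said of these compounds alone.

Of the compounds shown here, three built on one shared core have been tested in a functional assay on L02 cells (Homo sapiens) for inhibition, read by MTT assay, with a stated time of 48 h; on this read-out lower numbers stand for stronger inhibition and higher numbers for weaker inhibition. Among the compounds with values here, compound 1 `COc1ccc2c(=O)c(/C=C/C(=O)NCc3ccccc3F)coc2c1` is the first of them. In this assay compound 1 gives only a limit of the assay, > 200000 nM. Compound 2 `COc1ccc2c(=O)c(/C=C/C(=O)NCc3ccc(C)cc3)coc2c1` carries a different ring on the chain carbon bound to the amide nitrogen. Compound 2 also gives only a limit, > 200000 nM. Compound 3 `COc1ccc2c(=O)c(/C=C/C(=O)NCc3ccc(F)cc3F)coc2c1` bears two fluorines on that ring. Compound 3 likewise gives only a limit, > 200000 nM. The steps between them, a step that the two limits leave unreadable from compound 1 to compound 2, a step that the two limits leave unreadable from compound 1 to compound 3 and a step that the two limits leave unreadable from compound 2 to compound 3, have no readable size because every value sits at the limit of > 200000 nM in this assay, at which 3 of the 3 values shown sit.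

Compound 4 `COc1ccc2c(=O)c(/C=C/C(=O)Nc3ccc(C)cc3)coc2c1` differs from compound 3 by 4-methylphenyl in place of 2,4-difluorobenzyl on an amide-type nitrogen. Within the data shown here, none of the measured steps covers this change, and none of them has a readable size, so nothing points to a shift in either direction. Compound 4 is therefore expected to give about 300000 nM, with a range from 150000 nM to 2000000 nM. The step this estimate implies is a step that the limit leaves unreadable from compound 3 to compound 4, expected to stay within the scatter.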

Compound 4, half-maximal inhibitory concentration: > 200000 nM
Compound 4: no number, only a limit; the forecaster's own chance of this, stated with the estimate: 85%; the middle value lies beyond the limit too.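

Compound 4 also gives only a limit, so its steps from compound 1, compound 2 and compound 3 cannot be read, because all the values sit at the same limit: the limit of > 200000 nM in this assay, at which 4 of the 4 values shown sit.

The compounds shown leave open which group on the amide nitrogen, if any, would give a measurable value.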